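The compounds below may be only part of what the source reports. "The series", "measured", "known", "first", "only" and "open" are said of these compounds alone.

In a physicochemical assay, with a stated time of 30 min (on this read-out lower numbers stand for stronger inhibition and higher numbers for weaker inhibition), compound 1 `COc1cc2c(cc1OC)C(=O)C(C(=O)Nc1ccccc1)C2` gives 61.3 ug/mL and compound 2 `CCc1cccc(NC(=O)C2Cc3cc(OC)c(OC)cc3C2=O)c1` gives 64.1 ug/mL, values within the scatter of each other. Compound 3 `COc1ccccc1NC(=O)C1Cc2cc(OC)c(OC)cc2C1=O` has 2-methoxyphenyl in place of 3-ethylphenyl on an amide-type nitrogen. Going by the values given here, the one measured step that bears on this is a 1.0-fold higher number from compound 1 to compound 2 (0.02 log units; within the scatter), a change on the same aromatic ring. Among the compounds with values here, no measured step covers a methoxy group, so that single step is a thin guide, and no shift beyond the scatter is expected in this assay. The expected step is a 1.1-fold lower number from compound 2 to compound 3 (0.04 log units; within the scatter). Compound 3 is estimated at 58 ug/mL, with a range of 28 ug/mL to 115 ug/mL.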

Compound 3, half-maximal inhibitory concentration: 45.8 ug/mL
For compound 3 the middle estimate is 1.3-fold (0.10 log units) above the measured one; the range from low to high includes it.
By their numbers in this assay, from the lowest: compounds 3, 1 and 2 (each within the scatter of the next).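

In this assay the change to 2-methoxyphenyl from 3-ethylphenyl on the amide-type nitrogen gives a 1.4-fold lower number from compound 2 to compound 3 (0.15 log units; within the scatter) and the closest comparison, a single added methoxy group, gives a 1.3-fold lower number from compound 1 to compound 3 (0.13 log units; within the scatter). The aromatic ring on this nitrogen has now carried methoxy as well as ethyl, with no step beyond the scatter. No evidence is available that bears on these steps.

As far as these compounds go, whether an amine or a carboxylic acid on this ring would give a step beyond the scatter remains open, as does the effect of a longer chain in place of ethyl.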